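From bromo to iodo: a third halogen awaits measurement

The source may hold more compounds than are shown below. What is called first, only, known or untested is meant among the compounds shown, and "the series" means these compounds.

Compound 1 `O=C(CCc1cccc2c1B(O)OC2)Nc1ccc(F)cc1`: 440 nM
Compound 2 `O=C(CCc1cccc2c1B(O)OC2)Nc1ccc(Br)cc1`: 5300 nM

Within the data shown here, in a functional assay on MDA-MB-231 cells (Homo sapiens) for antiproliferative activity, read by MTT assay, with a stated time of 72 h (on this read-out lower numbers stand for stronger inhibition and higher numbers for weaker inhibition), compound 2 gives 5300 nM, the higher of the two numbers so far. Compound 3 `O=C(CCc1cccc2c1B(O)OC2)Nc1ccc(I)cc1` has not yet been measured. It carries iodo in place of bromo on an aromatic carbon, para to a large group: iodo in place of bromo on an aromatic carbon. Among the measured compounds shown here, only one measured step bears on this change: a 12-fold higher number from compound 1 to compound 2 (1.08 log units; beyond the scatter), with bromo in place of fluoro on an aromatic carbon. That step is large and lies beyond the scatter, but a single step sets no trend among the halogens. A small further rise in this assay is therefore expected, not a second large step: the expected change is a 1.3-fold higher number from compound 2 to compound 3 (0.12 log units; within the scatter), which would stay within the scatter. The estimated value for compound 3 is 7000 nM, with an expected range from 2500 nM to 20000 nM.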

Compound 3, half-maximal inhibitory concentration: 33000 nM
Estimate against measurement, compound 3: 4.7-fold (0.67 log units) below; the measured number lies above the stated range.
By their numbers in this assay, from the lowest: compound 1; then compound 2; then compound 3.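

In this assay, the second change on this aromatic carbon, para to a large group, again raises the number, giving a 6.2-fold higher number from compound 2 to compound 3 (0.79 log units; beyond the scatter), so the loss seen on going to bromo does not level off there. Taken end to end, the change gives a 75-fold higher number from compound 1 to compound 3 (1.88 log units; beyond the scatter), and the three compounds now stand in the order fluoro, bromo, iodo, with none going against it. Nothing in the information at hand accounts for this order.

The compounds shown leave open where chloro would stand in this order, and whether a hydrogen in place of the halogen would give a lower or a higher number than fluoro. They also leave open how a non-halogen group on the same carbon, such as a methoxy group, a nitrile or an amine, would compare with these three.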